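This account rests on a few compounds, and the source may have more. Where it says the series, first, only, none or still open, it means among the compounds named here.

Measured compounds and their values:

Compound 1, `C#CCOC(=O)C1=C(N)Oc2ccc(-c3cc(OC)cc(OC)c3)cc2C1CC(=O)c1ccccc1`: 5900 nM
Compound 2, `C#CCOC(=O)C1=C(N)Oc2ccc(-c3cc(OC)cc(OC)c3)cc2C1CC(O)c1ccccc1`: 54000 nM
Compound 3, `CCCC(=O)CC1C(C(=O)OCC)=C(N)Oc2ccc(-c3cc(OC)cc(OC)c3)cc21`: 11700 nM

In a functional assay on HL60/MX2 cells (Homo sapiens) for inhibition, with a stated time of 48 h (a higher number here means a weaker inhibitor, a lower number a stronger inhibitor), compound 3 gives 11700 nM. Compound 1 and compound 3 lie within the scatter of each other, so nothing separates them; compound 2 sits at a higher number than both, beyond the scatter.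

Compound 4, `C#CCOC(=O)C1=C(N)Oc2ccc(-c3cc(OC)cc(OC)c3)cc2C1CC(=O)CCC`, differs from compound 3 by ethynyl in place of methyl on a saturated chain carbon bound to an oxygen next to a carbonyl group. Among the measured compounds shown here, the only measured step, a 9.2-fold higher number from compound 1 to compound 2 (0.96 log units; beyond the scatter), concerns a different part of the molecule, the benzoyl group on the side chain, and says nothing about the ester. For the measured compounds named here, compound 1 and compound 3 differ in two places at once, the ester and the side chain, so no single step isolates the ester change; still, their values lie within the scatter of each other, which gives no sign that the ester matters much here.

On this basis the step from compound 3 to compound 4 is expected to be small, and the estimate is a 1.3-fold lower number from compound 3 to compound 4 (0.11 log units; within the scatter), not beyond the scatter in either direction. Compound 4 is therefore expected to give about 9000 nM, with a range from 3000 nM to 27000 nM.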

Compound 4, half-maximal inhibitory concentration: 5400 nM
Compound 4: middle estimate off by 1.7-fold (0.22 log units), on the high side; measured number inside the range.
By their numbers in this assay, from the lowest: compounds 4, 1 and 3 (each within the scatter of the next, the first and the last beyond it); then compound 2.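

In this assay, the ester gives its first single-place reading: propargyloxycarbonyl in place of ethoxycarbonyl brings a modest gain in strength that lies beyond the scatter (a 2.2-fold lower number from compound 3 to compound 4 (0.34 log units; beyond the scatter)), something compounds 1 and 3 could not show, as they differ in two places. With the propargyl ester held fixed, propyl and phenyl on the carbonyl carbon cannot be told apart (a 1.1-fold lower number from compound 1 to compound 4 (0.04 log units; within the scatter)), so in this pair the side chain's end group can change from a ring to a short chain with no measurable effect. Compound 2 remains clearly weaker than compound 4 (a 10-fold lower number from compound 2 to compound 4 (1.00 log units; beyond the scatter)), although that step replaces the whole hydroxy(phenyl)methyl group with propylcarbonyl, so it does not separate the carbonyl from the end group.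

Open questions are whether a plain propyl ester would match the propargyl ester, which would show if the triple bond matters or only the longer chain, and whether the ester step would be the same with phenyl on the carbonyl carbon. Nothing shown here offers an independent measurement that explains these differences.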